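From Fluoro to Carboxyethylcarbonyloxy: Expecting a Step

A few compounds are considered here, and "the series" means these few. Any claim that something is new, unique, unknown or untested is made for them only; others in the source may bear on it.

Compound 1, `CC(C)=CCC[C@@]1(C)CC=C(CF)c2oc(C)cc2[C@@H]1/C=C/OC(=O)C=C(C)C`, gives > 40000 nM in a functional assay on A549 cells (Homo sapiens) for antiproliferative activity, read by MTT assay, with a stated time of 48 h (a lower number here means a stronger inhibitor, a higher number a weaker inhibitor), a limit of the measurement rather than a number.
Compound 2, `CC(C)=CCC[C@@]1(C)CC=C(COC(=O)CCC(=O)O)c2oc(C)cc2[C@@H]1/C=C/OC(=O)C=C(C)C`, gives > 40000 nM in this assay, again a limit and not a number.
Compound 3, `CC(C)=CCC[C@@]1(C)CC=C(CF)c2nnc(C)cc2[C@@H]1/C=C/OC(=O)C=C(C)C`, gives 20500 nM in this assay.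

Among the compounds with values here, compound 3 thus holds the only number that was read; the two further values are limits. Compound 4, `CC(C)=CCC[C@@]1(C)CC=C(COC(=O)CCC(=O)O)c2nnc(C)cc2[C@@H]1/C=C/OC(=O)C=C(C)C`, has not yet been measured. It differs from compound 3 by ((2-carboxyethyl)carbonyl)oxy in place of fluoro on a saturated chain carbon bound to a double-bonded ring carbon.

The same exchange has been tried once before, as the step from compound 1 to compound 2, which reads a step that the two limits leave unreadable from compound 1 to compound 2. Because the limit of > 40000 nM in this assay, at which 2 of the 3 values shown sit, marks both ends of that step, it tells nothing about direction or size. Within the data shown here, no measured step therefore bears readably on the change to compound 4, and no shift beyond the scatter can be expected in either direction. The estimate for compound 4 is 25000 nM, spanning 8000 nM to 40000 nM, a step of a 1.2-fold higher number from compound 3 to compound 4 (0.09 log units; within the scatter) from compound 3 that is expected to stay within the scatter, with a real chance that only a limit is reported.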

Compound 4, half-maximal inhibitory concentration: > 40000 nM
Compound 4 gave a limit, no number; the forecaster's own chance of this, stated with the estimate: 40%; middle value at least 1.6-fold (0.20 log units) from the limit.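

At this position, on a saturated chain carbon bound to a double-bonded ring carbon, the exchange of fluoro for ((2-carboxyethyl)carbonyl)oxy now has a readable floor in this assay, where the earlier pair gave none: an at least 1.9-fold higher number from compound 3 to compound 4 (0.29 log units; that floor lies within the scatter). The step may be larger than this floor, but its true size cannot be read, and the earlier step between the two limits cannot be read at all. The reading stops at this floor because the measurement ends at a limit: the limit of > 40000 nM in this assay, at which 3 of the 4 values shown sit.

On these data alone, whether the true step lies beyond the scatter stays open. Also open, as far as these compounds go, is how a hydroxyl or an amine in place of fluoro at this position would read against compound 3, which gives 20500 nM in this assay.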